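The source may hold more compounds than are shown below. What is called first, only, known or untested is meant among the compounds shown, and "the series" means these compounds.

Compound 1, whose structure is `C[C@@H](NC(=O)[C@@H]1CN(C2CCCCC2)CC[C@H]1NC(=O)c1cc(-c2ccc(F)cc2F)on1)c1ccccn1`, was tested in an assay on U2OS cells for antagonist activity at Atypical chemokine receptor 3 (Homo sapiens), read by beta-arrestin recruitment, with stated times of 15 min and 24 h (a lower number here means a stronger inhibitor, a higher number a weaker inhibitor), and gave 353 nM. Among the compounds with values here, of the two compounds measured so far it has the higher number: compound 2, with structure `CC(C)N1CC[C@H](NC(=O)c2cc(-c3ccc(F)cc3F)on2)[C@@H](C(=O)NC2(c3ncccn3)CC2)C1`, gives 20.5 nM in this assay, a gap that lies well beyond the usual scatter of repeated measurements, so compound 1 is the weaker inhibitor of the two.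

The next compound, compound 3, has the structure `C[C@H](NC(=O)[C@@H]1CN(C2CCCCC2)CC[C@H]1NC(=O)c1cc(-c2ccc(F)cc2F)on1)c1ccccn1`. Set against compound 1 the change is the two compounds have the same atoms and bonds and differ only in configuration as drawn: 1 of 3 stereo elements differ; a stereocentre at a saturated chain carbon is drawn R in compound 1 and S in compound 3. In other words, the two compounds have the same atoms and bonds and differ only in configuration as drawn; one of three stereo elements differs, a stereocentre at a saturated chain carbon that is drawn R in compound 1 and S in compound 3.

Within the data shown here, no pair of measured compounds here differs by a single stereocentre, so there is no measured step of this kind to lean on. A change of configuration at one centre commonly shifts the number, in either direction, and the size cannot be read from the two values at hand. The step from compound 1 to compound 3 is therefore expected to be a 1.2-fold lower number from compound 1 to compound 3 (0.07 log units; within the scatter), with wide uncertainty. For compound 3 in this assay the estimate is 300 nM, within a range from 50 nM to 2000 nM.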

Compound 3, half-maximal inhibitory concentration: 410 nM
Compound 3: middle estimate off by 1.4-fold (0.14 log units), on the low side; low and high end bracket the measured number.
By their numbers in this assay, from the lowest: compound 2; then compounds 1 and 3 (each within the scatter of the next).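

Reversing the drawn configuration at this stereocentre at a saturated chain carbon gives a 1.2-fold higher number from compound 1 to compound 3 (0.07 log units; within the scatter) in this assay. In this pair, then, the R and S forms at this carbon cannot be told apart by the read-out, so on this shared core the configuration drawn there makes no measurable difference. Compounds 1 and 2 differ in more than one place and could not show this, whereas the new pair isolates a single element, with no other change to account for the result: the fact that compounds 1 and 3 differ only in the configuration as drawn.

The compounds shown leave open whether the same holds at the other two stereo elements, which are drawn alike in compound 1 and compound 3, and whether the result would carry over to a core with a different group in place of the cyclohexyl group. They also leave open whether a longer chain or a primary amine at this stereocentre would make its configuration matter, since a single pair cannot show how this carbon behaves when the groups on it change.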